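A few compounds are considered here, and "the series" means these few. Any claim that something is new, unique, unknown or untested is made for them only; others in the source may bear on it.

Measured so far:
- compound 1 `CCCCCCCCCCCCCCNC(=O)[C@H](CO)/N=C/c1cccc(Cl)c1`: in an ADME assay on HEK293 cells (Homo sapiens) for cytotoxicity (on this read-out lower numbers stand for stronger inhibition and higher numbers for weaker inhibition), compound 1 gives 77000 nM
- compound 2 `CCCCCCCCCCCCCCNC(=O)[C@H](CO)/N=C/c1ccc(O)cc1`: in this assay compound 2 gives 71700 nM

Compound 1 stands with the highest of the two numbers in this assay. Its nearest companion is compound 2, and the step of a 1.1-fold lower number from compound 1 to compound 2 (0.03 log units; within the scatter) lies within the scatter, so no order between the two can be claimed from these data.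

Compound 3 `CCCCCCCCCCCCCCNC(=O)[C@H](CO)/N=C/c1ccc(C)cc1` has not yet been measured. It differs from compound 1 in one place: 4-methylphenyl in place of 3-chlorophenyl on a carbon with a double bond to nitrogen. Among the compounds with values here, the only measured step that bears on this change is the one in which the ring on the carbon with a double bond to nitrogen was likewise exchanged, a 1.1-fold lower number from compound 1 to compound 2 (0.03 log units; within the scatter), and that step stayed within the scatter. On this basis a step of a 1.0-fold lower number from compound 1 to compound 3 (0.01 log units; within the scatter) in this assay is expected from compound 1 to compound 3, in no direction beyond the scatter. Compound 3 is therefore estimated at 75000 nM, with a range from 35000 nM to 160000 nM.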

Compound 3, half-maximal inhibitory concentration: 47300 nM
For compound 3 the middle estimate is 1.6-fold (0.20 log units) above the measured one, and the stated range covers the measured number.
By their numbers in this assay, from the lowest: compounds 3, 2 and 1 (each within the scatter of the next).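

In this assay the ring on the carbon with a double bond to nitrogen has now been exchanged a second time: 4-methylphenyl in place of 3-chlorophenyl gives a 1.6-fold lower number from compound 1 to compound 3 (0.21 log units; within the scatter) and stays within the scatter, so two different replacements at this position have now left the number without a change that can be read. Within the data shown here, the new compound also allows a comparison within the 4-substituted rings, which the earlier compounds did not offer: methyl in place of hydroxy on an aromatic carbon gives a 1.5-fold lower number from compound 2 to compound 3 (0.18 log units; within the scatter) and again lies within the scatter, so no order can be claimed among the three compounds. Nothing measured on hand offers a reason for the size of these steps.

What an amine or a carboxylic acid on this ring would do in this assay remains open, since the rings shown carry only chlorine, hydroxy or methyl. Also open, as far as these compounds go, is whether a shorter chain in place of the long alkyl chain of the shared core would move the number beyond the scatter, because that chain is the same in all three compounds.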